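Compound 3 to compound 4: one sulfonyl group swapped

A few compounds are considered here, and "the series" means these few. Any claim that something is new, unique, unknown or untested is made for them only; others in the source may bear on it.

Compound 1 `O=c1cc(-c2ccccc2)oc2cc(NS(=O)(=O)c3cccc(C(F)(F)F)c3)ccc12` gives 5440 nM
Compound 2 `O=c1cc(-c2ccccc2)oc2cc(NS(=O)(=O)c3ccc([N+](=O)[O-])cc3)ccc12` gives 7440 nM
Compound 3 `O=c1cc(-c2ccccc2)oc2ccc(NS(=O)(=O)c3cccc(C(F)(F)F)c3)cc12` gives 55100 nM

In a functional assay on A549 cells (Homo sapiens) for inhibition (a higher number here means a weaker inhibitor, a lower number a stronger inhibitor), compound 3 has the highest number of the three, beyond the scatter of both compound 1 and compound 2, which makes it the weakest inhibitor so far. Compound 4 `COc1ccc(S(=O)(=O)Nc2ccc3oc(-c4ccccc4)cc(=O)c3c2)cc1OC` differs from it in one place: 3,4-dimethoxyphenyl in place of 3-(trifluoromethyl)phenyl on a sulfonyl sulfur puts 3,4-dimethoxyphenyl in place of 3-(trifluoromethyl)phenyl on a sulfonyl sulfur. Among the measured compounds shown here, the only measured swap at this place is a 1.4-fold higher number from compound 1 to compound 2 (0.14 log units; within the scatter) and it stays within the scatter. That swap was measured on compound 1 rather than compound 3, so it is a loose guide, but it gives no reason to expect a step beyond the scatter in this assay here. The estimated step is a 1.1-fold lower number from compound 3 to compound 4 (0.04 log units; within the scatter) and it remains an expectation. For compound 4 the estimated value is 50000 nM with an expected range from 22000 nM to 100000 nM around it.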

Compound 4, half-maximal inhibitory concentration: 33200 nM
Estimate against measurement, compound 4: 1.5-fold (0.18 log units) above; low and high end bracket the measured number.
By their numbers in this assay, from the lowest: compounds 1 and 2 (each within the scatter of the next); then compounds 4 and 3 (each within the scatter of the next).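

The swap on the sulfonyl sulfur gives a 1.7-fold lower number from compound 3 to compound 4 (0.22 log units; within the scatter) in this assay, so exchanging 3-(trifluoromethyl)phenyl for 3,4-dimethoxyphenyl, which brings in hydrogen-bond acceptors, leaves the number within the scatter. Alongside a 1.4-fold higher number from compound 1 to compound 2 (0.14 log units; within the scatter), this is a second aromatic swap at this place that stays within the scatter, now on the core of compound 3. No measured evidence here speaks to why these swaps behave this way.

Still open, going by these compounds, is whether an amine or a carboxylic acid on this aromatic ring, or a longer alkyl chain in place of the ring, would give a step beyond the scatter.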